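This account rests on a few compounds, and the source may have more. Where it says the series, first, only, none or still open, it means among the compounds named here.

Measured compounds:
compound 1 `COc1ccc(Cn2cc(CNC(=O)c3cn(-c4ccccc4)nc3-c3ccccc3)nn2)cc1`, in a functional assay on MIA PaCa-2 cells (Homo sapiens) for antiproliferative activity, read by sulforhodamine B assay, with a stated time of 48 h (a higher number here means a weaker inhibitor of growth, a lower number a stronger inhibitor of growth), compound 1 gives 10200 nM.
compound 2 `COc1cc(Cn2cc(CNC(=O)c3cn(-c4ccccc4)nc3-c3ccccc3)nn2)cc(OC)c1`, in this assay compound 2 gives 190 nM.

Among the measured compounds shown here, of the two numbers so far, compound 2 stands at the lower one, and the only step among the measured compounds, a 54-fold lower number from compound 1 to compound 2 (1.73 log units; beyond the scatter), separates it from compound 1. That step changes the benzyl part on the triazole side of the shared core and leaves the phenyl groups on the other side untouched.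

Compound 3 `COc1cc(Cn2cc(CNC(=O)c3cn(-c4ccccc4)nc3-c3ccc(Cl)cc3)nn2)cc(OC)c1` keeps the 3,5-dimethoxyphenyl of compound 2 and differs from it only by chloro in place of hydrogen on an aromatic carbon, that is, phenyl to 4-chlorophenyl. For the measured compounds named here, no measured step touches this phenyl, so the one step in hand, a 54-fold lower number from compound 1 to compound 2 (1.73 log units; beyond the scatter), does not speak to it. Without a precedent, the expectation for compound 3 in this assay is a number near that of compound 2, the step of no change at the digits printed from compound 2 to compound 3 (within the scatter) expected to stay within the scatter. Compound 3 is therefore estimated at 190 nM, with a range from 50 nM to 700 nM.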

Compound 3, concentration for 50% growth inhibition: 340 nM
For compound 3 the middle estimate is 1.8-fold (0.25 log units) below the measured one, and the stated range covers the measured number.
By their numbers in this assay, from the lowest: compounds 2 and 3 (each within the scatter of the next); then compound 1.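

In this assay, chloro in place of hydrogen on this aromatic carbon, para to a large group, gives a 1.8-fold higher number from compound 2 to compound 3 (0.25 log units; within the scatter), so this change cannot be told apart from no change. Among the compounds shown here, this is the first reading at this phenyl, which the earlier step left untouched, and it shows that with the 3,5-dimethoxyphenyl held fixed, the position takes a single chlorine atom without a change beyond the scatter. No available evidence bears on this result.

On these data alone, whether larger or different groups at this position, such as an amine, a carboxylic acid or a longer chain, would also stay within the scatter remains open. Also open, as far as these compounds go, is whether chloro would read the same on the other phenyl of the shared core, or alongside the 4-methoxyphenyl of compound 1.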